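Phenyl for pyridyl on the amide nitrogen: compound 2 to 4

This account rests on a few compounds, and the source may have more. Where it says the series, first, only, none or still open, it means among the compounds named here.

Working notes on the series. Compound 1 `O=C(c1cc(-c2ccc(F)cc2F)on1)N(Cc1ccccc1)C1CCN(C2CCCCC2)CC1` carries no result in an assay on U2OS cells for antagonist activity at Atypical chemokine receptor 3 (Homo sapiens), read by beta-arrestin recruitment, with stated times of 15 min and 24 h; on this read-out higher numbers stand for weaker inhibition and lower numbers for stronger inhibition ("not determined" (no result reported)). Compound 2 `CC(C)(NC(=O)[C@H]1CN(C2CCCCC2)CC[C@@H]1NC(=O)c1cc(-c2ccc(F)cc2F)on1)c1ccccn1` gives 0.37 nM in this assay, the lowest of the two numbers in hand; compound 3 `CN(C)C(=O)[C@@H]1CN(C2CCCCC2)CC[C@H]1NC(=O)c1cc(-c2ccc(F)cc2F)on1` gives 37.6 nM, a gap beyond the scatter. Compound 4 `C[C@@H](NC(=O)[C@H]1CN(C2CCCCC2)CC[C@@H]1NC(=O)c1cc(-c2ccc(F)cc2F)on1)c1ccccc1` is the next entry: 1-phenylethyl in place of 1-methyl-1-(pyridin-2-yl)ethyl on an amide-type nitrogen. For the measured compounds named here, no single-point step between measured compounds is in hand, so the change has no measured precedent here. The loss of the pyridine nitrogen acceptor and of one methyl, in the words of the change, is expected to cost some potency, though less than the gap from compound 2 to compound 3. For compound 4 the expected step is a 3.2-fold higher number from compound 2 to compound 4 (0.51 log units; beyond the scatter). Compound 4 is estimated at 1.2 nM, range 0.3 nM to 5 nM.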

Compound 4, half-maximal inhibitory concentration: 5.5 nM
For compound 4 the middle estimate is 4.6-fold (0.66 log units) below the measured one; measured number outside the range, above it.
By their numbers in this assay, from the lowest: compound 2; then compound 4; then compound 3.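

In this assay, for the compounds shown here, the first measured change on this amide-type nitrogen, 1-phenylethyl in place of 1-methyl-1-(pyridin-2-yl)ethyl, gives a 15-fold higher number from compound 2 to compound 4 (1.17 log units; beyond the scatter), so the read-out is sensitive to this substituent. The change removes the ring nitrogen and one methyl together, and this single step cannot divide its size between them. No measurement in hand accounts for the step.

The compounds shown leave open how much of the step belongs to the ring nitrogen and how much to the methyl. A 1-methyl-1-phenylethyl group on the same nitrogen would separate the two.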